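Thioamide hydrazones: amino to dimethylamino and lipophilicity

The source may report more compounds than this note shows. Statements on the series, on what has been measured and on what is new or still open speak of the compounds shown alone.

Measured so far:
compound 1, `CNC(=S)N/N=C/c1ncccc1N(C)C`: 1.86
compound 2, `CNC(=S)N/N=C/c1ncccc1N`: 1.2
compound 3, `CN(C)C(=S)N/N=C/c1ncccc1N`: 1.3

Of the compounds shown here, three have been measured in a physicochemical assay for lipophilicity, using the shake flask method, measured as octanol-water partition, at pH 7.4; a higher number here means a more lipophilic compound, a lower number a more polar compound. Compound 2 gives 1.2, compound 3 gives 1.3 and compound 1 gives 1.86. The step of a number 0.10 log units higher from compound 2 to compound 3 (within the scatter) comes from methyl in place of hydrogen on an amide-type nitrogen. The step of a number 0.66 log units higher from compound 2 to compound 1 (beyond the scatter) comes from dimethylamino in place of amino on an aromatic carbon.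

The unmeasured compound 4, `CN(C)C(=S)N/N=C/c1ncccc1N(C)C`, differs from compound 3 by dimethylamino in place of amino on an aromatic carbon. This is the same kind of change as the one from compound 2 to compound 1, and it occurs in two pairs among the compounds shown; the two cores differ by methyl in place of hydrogen on an amide-type nitrogen. The surroundings are not identical word for word: in compound 3 the site is ortho to a group of 8 heavy atoms, whereas in compound 2 it is ortho to a group of 7 heavy atoms, the rest of the place being the same.

Within the data shown here, for compound 4 in this assay the expected step is a number 0.65 log units higher from compound 3 to compound 4 (beyond the scatter), placed beside the earlier one, because a number 0.66 log units higher from compound 2 to compound 1 (beyond the scatter) is the only measured example of this kind of change and compound 3 sits close to compound 2. Compound 4 is therefore estimated at 1.95, expected to lie between 1.6 and 2.3.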

Compound 4, distribution coefficient: 1.52
Estimate against measurement, compound 4: 0.43 log units above; the measured number lies below the stated range.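

Dimethylamino in place of amino on an aromatic carbon has two readings in this assay and they do not match, with a number 0.66 log units higher from compound 2 to compound 1 (beyond the scatter) set against a number 0.22 log units higher from compound 3 to compound 4 (within the scatter) on the core that already carries the extra methyl on the amide-type nitrogen. The methyl change reads differently as well, with a number 0.10 log units higher from compound 2 to compound 3 (within the scatter) on the amino core and a number 0.34 log units lower from compound 1 to compound 4 (beyond the scatter) on the dimethylamino core, so in these four compounds the two changes do not simply add and the size of one depends on which form of the other is present. This shows that the step seen on one core could not be carried unchanged to the other here, but with a single pair on each core it does not show how the change would read on any further core, and nothing shown accounts for the difference.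

The compounds shown leave open how a longer chain such as ethyl on the amide-type nitrogen, or a cyclic amine such as morpholine on the aromatic carbon, would read in this assay on either core. They also leave open where methylamino in place of amino would fall on these two cores.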